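Amide aryl variation on the flavonol series

The source may hold more compounds than are shown below. What is called first, only, known or untested is meant among the compounds shown, and "the series" means these compounds.

Measured so far:
Compound 1 `COc1ccc(C(=O)Nc2cccc(-c3oc4cc(-c5ccc(F)cc5)ccc4c(=O)c3O)c2)cc1` gives 8420 nM in a functional assay on HepG2 cells (Homo sapiens) for antiproliferative activity, read by CCK-8 assay, with a stated time of 72 h; a higher number here means a weaker inhibitor, a lower number a stronger inhibitor.
Compound 2 `O=C(Nc1cccc(-c2oc3cc(-c4ccc(F)cc4)ccc3c(=O)c2O)c1)c1ccc(F)cc1F` gives 26400 nM in this assay.
Compound 3 `Cc1cc(C)cc(C(=O)Nc2cccc(-c3oc4cc(-c5ccc(F)cc5)ccc4c(=O)c3O)c2)c1` gives 13400 nM in this assay.

Compound 3 sits second highest of the three numbers; its nearest neighbour is compound 1 a 1.6-fold higher number from compound 1 to compound 3 (0.20 log units; within the scatter) and its furthest is compound 2 a 2.0-fold lower number from compound 2 to compound 3 (0.29 log units; within the scatter), both inside the usual scatter. For the measured compounds named here, the only step beyond the scatter is a 3.1-fold higher number from compound 1 to compound 2 (0.50 log units; beyond the scatter), and even that is modest.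

Compound 4 `N#Cc1ccc(C(=O)Nc2cccc(-c3oc4cc(-c5ccc(F)cc5)ccc4c(=O)c3O)c2)cc1` differs from compound 3 by 4-cyanophenyl in place of 3,5-dimethylphenyl on a carbonyl carbon. Every change made so far at this carbonyl carbon, whether to 4-methoxyphenyl, 2,4-difluorophenyl or 3,5-dimethylphenyl, has moved this assay by little: two of the three steps stay within the scatter and the third is modest. Going by the values given here, no step with 4-cyanophenyl exists in this set, so the expectation for compound 4 rests on the narrow spread of compounds 1, 2 and 3. For compound 4 the step is expected to be a 1.1-fold higher number from compound 3 to compound 4 (0.05 log units; within the scatter), most likely within the scatter. Compound 4 is therefore estimated at 15000 nM in this assay, with a range from 6000 nM to 40000 nM.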

Compound 4, half-maximal inhibitory concentration: 7110 nM
Estimate against measurement, compound 4: 2.1-fold (0.32 log units) above; low and high end bracket the measured number.
By their numbers in this assay, from the lowest: compounds 4, 1, 3 and 2 (each within the scatter of the next, the first and the last beyond it).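

In this assay, the change to 4-cyanophenyl on the carbonyl carbon gives a 1.9-fold lower number from compound 3 to compound 4 (0.28 log units; within the scatter) and a 1.2-fold lower number from compound 1 to compound 4 (0.07 log units; within the scatter), so cyano in place of methoxy on an aromatic carbon does not separate compound 4 from compound 1. For the compounds shown here, the remaining new step, a 3.7-fold lower number from compound 2 to compound 4 (0.57 log units; beyond the scatter), is the widest at this position so far, and both steps beyond the scatter now involve compound 2, although its step to compound 3 stays within the scatter. No available measurement accounts for these differences.

From the compounds shown here alone, all four compounds carry a substituted phenyl on this carbonyl carbon, so it remains open whether an aminomethyl group, a carboxylic acid or a longer alkyl chain there would stay within this narrow range. Going by these compounds, whether the same amide groups would behave alike on a changed core also remains open.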